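Cytotoxicity notes: from compound 2 to compound 4

This account rests on a few compounds, and the source may have more. Where it says the series, first, only, none or still open, it means among the compounds named here.

compound 1 `O=C(N/N=C/c1ccccc1F)c1cnccn1`: 100%
compound 2 `O=C(N/N=C/c1cccc(Br)c1)c1cnccn1`: 100%
compound 3 `O=C(N/N=C/c1ccc(Br)cc1)c1cnccn1`: 100%

Of the compounds shown here, three on a shared core have been measured. In an ADME assay on J774 cells (Mus musculus) for cytotoxicity, read by MTT assay, with a stated time of 48 h, tested at 50 ug/mL (on this read-out higher numbers stand for a weaker effect at the one concentration tested and lower numbers for a stronger effect), compound 1 gives 100%, compound 2 gives 100% and compound 3 gives 100%. Compound 2 therefore stands level with compound 1 and compound 3 at the digits shown; the gap to compound 1 and the gap to compound 3 both lie within the scatter of this read-out. Among the compounds with values here, none of the three shows any effect on cell viability at the single concentration tested, and no step between measured compounds that differ in one place is available.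

Compound 4 `N#Cc1cccc(/C=N/NC(=O)c2cnccn2)c1` has not yet been measured in this assay. It differs from compound 2 as follows: cyano in place of bromo on an aromatic carbon. The change sits meta to a large group.

With all three measured compounds at the same reading, there is nothing to suggest that a change of this kind moves the number. The expected step is no change at the digits printed from compound 2 to compound 4 (within the scatter), that is, none beyond the scatter. Compound 4 is estimated to give 100%, with a range from 88% to 100%.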

Compound 4, a percentage reported as activity, at one concentration (the size of the read-out at that concentration, not a potency): 100%
For compound 4 middle estimate and measured number coincide at the digits printed, and the stated range covers the measured number.
By their numbers in this assay, from the lowest: compounds 1, 2, 3 and 4 (each within the scatter of the next).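

In this assay, within the data shown here, cyano in place of bromo on an aromatic carbon, meta to a large group, gives no change at the digits printed from compound 2 to compound 4 (within the scatter) and so provides the first step that isolates a single change. At this position, one bromine atom gives way to a carbon and a nitrogen, bringing in a triple bond and a hydrogen-bond acceptor, and the reading at the one concentration tested does not register the exchange. No measurement is available that bears on the reason for this outcome.

The compounds shown leave open whether an amine, a carboxylic acid or a longer chain on this same aromatic carbon would move the reading away from the level shared by all four compounds. With no step beyond the scatter in view, they also leave open which structural change, at this position or elsewhere on the shared core, would produce a lower reading on this cell line at all.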